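Three limits and a fourth compound to come

This account rests on a few compounds, and the source may have more. Where it says the series, first, only, none or still open, it means among the compounds named here.

Compound 1 `C/C(=C\CC/C(C)=C/CC[C@@H]1[C@@]2(C)CCC(=O)C(C)(C)[C@H]2CC[C@@]1(C)O)CC/C=C(\C)C(=O)OCc1cn(-c2ccc(F)cc2)nn1` — > 150000 nM
Compound 2 `C/C(=C\CC/C(C)=C/CC[C@@H]1[C@@]2(C)CCC(=O)C(C)(C)[C@H]2CC[C@@]1(C)O)CC/C=C(\C)C(=O)OCc1cn(-c2ccc(C(F)(F)F)cc2)nn1` — > 150000 nM
Compound 3 `C/C(=C\CC/C(C)=C/CC[C@@H]1[C@@]2(C)CCC(=O)C(C)(C)[C@H]2CC[C@@]1(C)O)CC/C=C(\C)C(=O)OCc1cn(-c2ccccc2[N+](=O)[O-])nn1` — > 150000 nM

In an ADME assay on L132 cells (Homo sapiens) for cytotoxicity, read by MTT assay, with a stated time of 48 h (a lower number here means a stronger inhibitor, a higher number a weaker inhibitor), compound 1 gives only a limit, > 150000 nM. Compound 2 likewise gives only a limit, > 150000 nM. Compound 3 also gives only a limit, > 150000 nM. All three values sit at the limit of > 150000 nM in this assay, at which 3 of the 3 values shown sit, so the steps between them cannot be read: a step that the two limits leave unreadable from compound 1 to compound 2, a step that the two limits leave unreadable from compound 1 to compound 3 and a step that the two limits leave unreadable from compound 2 to compound 3. Compound 2 therefore stands at the limit, together with the two others, and no ordering among the three can be drawn.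

Compound 4 `C/C(=C\CC/C(C)=C/CC[C@@H]1[C@@]2(C)CCC(=O)C(C)(C)[C@H]2CC[C@@]1(C)O)CC/C=C(\C)C(=O)OCc1cn(-c2ccccc2Br)nn1` has not yet been measured. It differs from compound 2 in one place: 2-bromophenyl in place of 4-(trifluoromethyl)phenyl on an aromatic nitrogen. The measured step that bears most closely on it is a step that the two limits leave unreadable from compound 2 to compound 3, also an exchange of the group on the aromatic nitrogen, and its size is not readable. Nothing measured here separates the three compounds, so no step beyond the scatter is expected in this assay in either direction. Compound 4 is expected to give 150000 nM, between 80000 nM and 400000 nM, most likely again as a limit. The expected step is a number no higher from compound 2 to compound 4 (the limit leaves the size open).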

Compound 4, half-maximal inhibitory concentration: > 150000 nM
Compound 4: no number, only a limit (the forecaster's own chance of this, stated with the estimate: 85%); the middle value lies on the limit itself.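

In this assay compound 4 also gives only a limit, > 150000 nM. Its steps to compound 1, compound 2 and compound 3 therefore cannot be read: the limit of > 150000 nM in this assay, at which 4 of the 4 values shown sit.

None of the four compounds gives a number, so they leave open whether the group on the aromatic nitrogen changes this read-out at all.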